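The source may report more compounds than this note shows. Statements on the series, on what has been measured and on what is new or still open speak of the compounds shown alone.

Two sulfonamides carrying the same core have been measured in a functional assay on MCF7 cells (Homo sapiens) for inhibition, read by MTT assay, with a stated time of 72 h; a higher number here means a weaker inhibitor of growth, a lower number a stronger inhibitor of growth. Compound 1 `O=S(=O)(NCCCCNCc1ccc(Br)cc1)c1cc(C(F)(F)F)cc(C(F)(F)F)c1` gives 1500 nM in this assay, and compound 2 `COc1ccc(CNCCCNS(=O)(=O)c2cc(C(F)(F)F)cc(C(F)(F)F)c2)cc1OC` gives 1900 nM in this assay. Compound 1 holds the lowest of the two numbers, but compound 2 sits so close that the two values cannot be told apart within the usual scatter, so neither can be called the stronger inhibitor of growth.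

Compound 3 `CN(CCCNS(=O)(=O)c1cc(C(F)(F)F)cc(C(F)(F)F)c1)Cc1ccccc1` has not yet been measured in this assay. Against compound 1 it shows one change: benzyl(methyl)amino in place of ((4-bromobenzyl)amino)methyl on a saturated chain carbon, three bonds along the chain from a sulfonamide nitrogen. Among the measured compounds shown here, no measured pair in this set shows what such a change does, so any expectation rests on the structural change alone. The loss of the bromine and the shorter chain leave the sulfonamide core unchanged, and a step in this assay of modest size, if any, toward a higher number is expected, a 1.7-fold higher number from compound 1 to compound 3 (0.22 log units; within the scatter). Compound 3 is therefore expected to give about 2500 nM in this assay, with a plausible range from 1000 nM to 6500 nM.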

Compound 3, concentration for 50% growth inhibition: 16000 nM
Beside the measured number, compound 3's estimate is 6.4-fold (0.81 log units) below it, outside the stated range (above it).
By their numbers in this assay, from the lowest: compounds 1 and 2 (each within the scatter of the next); then compound 3.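

Benzyl(methyl)amino in place of ((4-bromobenzyl)amino)methyl, on a saturated chain carbon three bonds along the chain from a sulfonamide nitrogen, is far from a silent change: in this assay it gives an 11-fold higher number from compound 1 to compound 3 (1.03 log units; beyond the scatter). Among the compounds shown here, compounds 1 and 2 lay within the scatter of each other and gave no sign that this part of the molecule could shift the number so far. The change takes away the bromine and the hydrogen-bond donor together, and no measurement offered here explains the rise.

Which part of the change carries the step remains open. A plain benzylamino group or a (4-bromobenzyl)(methyl)amino group in the same place would help separate the bromine from the methyl on the amine nitrogen.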